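The source may hold more compounds than are shown below. What is called first, only, known or untested is meant among the compounds shown, and "the series" means these compounds.

Three compounds have been measured in a functional assay on SW480 cells (Homo sapiens) for cytotoxicity, read by MTT assay, with a stated time of 48 h; a lower number here means a stronger inhibitor, a higher number a weaker inhibitor:

- compound 1, `Cc1ccc(Cn2cc(COc3ccc4c(=O)ccoc4c3)nn2)cc1`, gives 10400 nM.
- compound 2, `O=c1ccoc2cc(OCc3cn(Cc4ccc(F)cc4)nn3)ccc12`, gives 11200 nM.
- compound 3, `N#Cc1ccc(Cn2cc(COc3ccc4c(=O)ccoc4c3)nn2)cc1`, gives only a limit of the assay, > 100000 nM.

Among these, compound 2 and compound 1 lie within the usual scatter of one another, so neither can be called the stronger; the step of a 1.1-fold higher number from compound 1 to compound 2 (0.03 log units; within the scatter) confirms this. The third value is a limit: the limit of > 100000 nM in this assay, at which 1 of the 3 values shown sits.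

Compound 4, `COc1ccc(Cn2cc(COc3ccc4c(=O)ccoc4c3)nn2)cc1`, has not yet been measured. It differs from compound 2 in one place: methoxy in place of fluoro on an aromatic carbon.

Among the compounds with values here, two measured steps bear on this change. Replacing methyl with fluoro, a 1.1-fold higher number from compound 1 to compound 2 (0.03 log units; within the scatter), left the number essentially unchanged. Replacing methyl or fluoro with cyano, an at least 9.6-fold higher number from compound 1 to compound 3 (0.98 log units; beyond the scatter) and an at least 8.9-fold higher number from compound 2 to compound 3 (0.95 log units; beyond the scatter), pushed the value beyond the assay limit. A methoxy group has not been tried here, so there is no direct precedent, and no measured reason is available to favour one outcome.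

Given that exchange of methyl and fluoro produced no step beyond the scatter, the expectation for compound 4 is a step of about a 1.2-fold higher number from compound 2 to compound 4 (0.06 log units; within the scatter), that is, no clear change. The estimated value for compound 4 in this assay is therefore 13000 nM, with a likely range from 5000 nM to 40000 nM.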

Compound 4, half-maximal inhibitory concentration: 20400 nM
Estimate against measurement, compound 4: 1.6-fold (0.20 log units) below, within the range that was stated.
By their numbers in this assay, from the lowest: compounds 1, 2 and 4 (each within the scatter of the next). At a limit, above all of these: compound 3.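

In this assay, the change from fluoro to methoxy gives a 1.8-fold higher number from compound 2 to compound 4 (0.26 log units; within the scatter), and the change from methyl to methoxy gives a 2.0-fold higher number from compound 1 to compound 4 (0.29 log units; within the scatter). The position on the aromatic ring, para to a large group, therefore accepts an oxygen-linked group of two heavy atoms as well as methyl or fluoro, with no step beyond the scatter, and only compound 3 goes against this grouping. The change from cyano to methoxy gives an at least 4.9-fold lower number from compound 3 to compound 4 (0.69 log units; beyond the scatter), which shows that the separation of compound 3 from the others holds against a third group, though compound 3 is read only as a limit, not as a number: the limit of > 100000 nM in this assay, at which 1 of the 4 values shown sits.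

The compounds shown leave open how an amine, a carboxylic acid or a longer chain such as butoxy would read at this position, and whether a second group with a nitrile's triple bond, such as ethynyl, would also separate from the rest. They also cannot tell why cyano alone stands apart among these four groups, or whether the same order would hold elsewhere on the ring.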